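This account rests on a few compounds, and the source may have more. Where it says the series, first, only, none or still open, it means among the compounds named here.

Compound 1 `CCCCC#Cc1cc([C@@H]2O[C@H](CO)[C@@H](O)[C@H]2O)n2ncnc(N)c12` gives 1000 nM.
Compound 2 `Nc1ncnn2c([C@@H]3O[C@H](CO)[C@@H](O)[C@H]3O)cc(-c3ccccc3)c12` gives 75100 nM.
Compound 3 `Nc1ncnn2c([C@@H]3O[C@H](CO)[C@@H](O)[C@H]3O)cc(-c3ccc(F)cc3F)c12` gives 43500 nM.
Compound 4 `COc1ccc(-c2cc([C@@H]3O[C@H](CO)[C@@H](O)[C@H]3O)n3ncnc(N)c23)cc1` is not yet measured.

In a functional assay on LN-229 cells (Homo sapiens) for antiproliferative activity, with a stated time of 72 h (on this read-out higher numbers stand for weaker inhibition and lower numbers for stronger inhibition), compound 3 gives 43500 nM, within the scatter of compound 2 and far from compound 1. Compound 4 carries 4-methoxyphenyl in place of 2,4-difluorophenyl on an aromatic carbon. For the measured compounds named here, the closest precedent is one substituted or plain phenyl exchanged for another, a 1.7-fold lower number from compound 2 to compound 3 (0.24 log units; within the scatter), and it stays within the scatter. The large steps, a 75-fold higher number from compound 1 to compound 2 (1.88 log units; beyond the scatter) and a 44-fold higher number from compound 1 to compound 3 (1.64 log units; beyond the scatter), both remove hex-1-yn-1-yl, which this change does not. No step beyond the scatter is therefore expected in this assay. The expected change is a 1.1-fold higher number from compound 3 to compound 4 (0.06 log units; within the scatter). Compound 4 is estimated at 50000 nM, within a range of 18000 nM to 110000 nM.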

Compound 4, half-maximal inhibitory concentration: 40300 nM
Beside the measured number, compound 4's estimate is 1.2-fold (0.09 log units) above it; the range from low to high includes it.
By their numbers in this assay, from the lowest: compound 1; then compounds 4, 3 and 2 (each within the scatter of the next).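

In this assay, 4-methoxyphenyl on this aromatic carbon of the five-membered ring cannot be told apart from the other aryl groups: a 1.1-fold lower number from compound 3 to compound 4 (0.03 log units; within the scatter) and a 1.9-fold lower number from compound 2 to compound 4 (0.27 log units; within the scatter), so neither the exchange of substituted phenyls nor methoxy in place of hydrogen registers here. The hex-1-yn-1-yl compound stays apart from a third aryl group, with a 40-fold higher number from compound 1 to compound 4 (1.61 log units; beyond the scatter). Nothing measured here accounts for that gap. The compounds shown leave open whether the alkyne or the chain length sets compound 1 apart. A saturated hexyl chain or a shorter prop-1-yn-1-yl group on this carbon would separate the two.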